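Amide series on NUGC-3 cells: three limits, one open

A few compounds are considered here, and "the series" means these few. Any claim that something is new, unique, unknown or untested is made for them only; others in the source may bear on it.

Measured compounds:
compound 1 `O=C(Nc1ccc(C(F)(F)F)cc1)c1nccc2ccccc12` — > 10000 nM
compound 2 `COc1ccc(NC(=O)c2nccc3ccccc23)cc1` — > 10000 nM
compound 3 `O=C(Nc1cccc(C(F)(F)F)c1)C1NCCc2ccccc21` — > 10000 nM

All three were run in a functional assay on NUGC-3 cells (Homo sapiens) for inhibition, read by sulforhodamine B assay, with a stated time of 48 h; on this read-out lower numbers stand for stronger inhibition of growth and higher numbers for weaker inhibition of growth. For compound 1 the value is a limit of the assay, > 10000 nM. For compound 2 the value is likewise a limit, > 10000 nM. For compound 3 the value is again a limit, > 10000 nM. The change from compound 1 to compound 2 is methoxy in place of trifluoromethyl on an aromatic carbon. The step it made, a step that the two limits leave unreadable from compound 1 to compound 2, cannot be read because the limit of > 10000 nM in this assay, at which 3 of the 3 values shown sit, holds both values. The difference between the core of compound 1 and the core of compound 3 is not broken down here.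

Compound 4 `COc1cccc(NC(=O)C2NCCc3ccccc32)c1` is not yet measured. Its difference from compound 3 is methoxy in place of trifluoromethyl on an aromatic carbon. For the measured compounds named here, this is the same kind of change as the one from compound 1 to compound 2, but not the same: there the methoxy enters para to a large group, here meta to a large group.

The step from compound 3 to compound 4 is expected to be a step that the limit leaves unreadable from compound 3 to compound 4, and this expectation rests only on compound 3 sitting at the limit > 10000 nM and on compound 2, whose value after the same kind of change stays at a limit, > 10000 nM. In this assay compound 4 is estimated at 20000 nM, between 7000 nM and 80000 nM, with a limit rather than a number the most likely report.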

Compound 4, concentration for 50% growth inhibition: > 10000 nM
Compound 4: a limit, no number (the forecaster's own chance of this, stated with the estimate: 85%); the middle value is on the limit's open side.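

The step from compound 3 to compound 4 in this assay cannot be read, and neither can any other step in the series, because both ends of each step are limits and not numbers: the limit of > 10000 nM in this assay, at which 4 of the 4 values shown sit.

The compounds shown leave open whether either core can give a readable growth-inhibition value, and so how much methoxy in place of trifluoromethyl changes it on either core.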